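The source may hold more compounds than are shown below. What is called first, only, known or untested is meant among the compounds shown, and "the series" means these compounds.

In a functional assay on Vero cells (Chlorocebus sabaeus) for inhibition (on this read-out lower numbers stand for stronger inhibition and higher numbers for weaker inhibition), three compounds have been measured: compound 1 (`Nc1ccn([C@H]2O[C@@H](CO)C=C2F)c(=O)n1`), compound 2 (`Nc1ncnc2c1ncn2[C@@H]1O[C@@H](CO)C=C1F`) and compound 3 (`OC[C@H]1C=C(F)[C@H](n2cnc3c(O)ncnc32)O1`). Compound 1 gives > 100000 nM, a limit of the assay and not a number. Compound 2 gives > 100000 nM, also a limit. Compound 3 gives > 100000 nM, again a limit, so it has no number of its own and shares (the limit of > 100000 nM in this assay, at which 3 of the 3 values shown sit). Among the compounds with values here, the one measured step, a step that the two limits leave unreadable from compound 2 to compound 3, offers no size to carry forward. Compound 4 (`OC[C@H]1C=C(F)[C@@H](n2cnc3c(O)ncnc32)O1`) departs from compound 3 in this way: the two compounds have the same atoms and bonds and differ only in configuration as drawn: 1 of 2 stereo elements differ; a stereocentre at a saturated ring carbon is drawn R in compound 3 and S in compound 4. Within the data shown here, no measured step tests such a change. Given that shared limit, the expected move, a number no higher from compound 3 to compound 4 (the limit leaves the size open), is none beyond the scatter in this assay. Compound 4 is estimated at 100000 nM, with an expected range from 50000 nM to 200000 nM.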

Compound 4, half-maximal inhibitory concentration: > 100000 nM
Compound 4: a limit, no number; the forecaster's own chance of this, stated with the estimate: 90%; the middle value lies on the limit itself.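

Compound 3 and compound 4 both stand at a limit, not a number, in this assay, and the step between them cannot be read. The compounds shown leave open what true value any of them has, and whether configuration matters here: the limit of > 100000 nM in this assay, at which 4 of the 4 values shown sit.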